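The compounds below may be only part of what the source reports. "The series", "measured", "known", "first", "only" and "open" are said of these compounds alone.

In a physicochemical assay for lipophilicity, using the shake flask method, measured as octanol-water partition, at pH 7.4 (on this read-out lower numbers stand for lower lipophilicity and higher numbers for higher lipophilicity), compound 2 `CC(=O)N[C@@H]1CCC[C@H](C(=O)Nc2cc(-c3cnn4c3CCCCC4)c(Cl)cn2)C1` stands highest at 3.6, with compound 1 `CC(=O)N[C@@H]1CCC[C@H](C(=O)Nc2cc(-c3cnc(C)n3C)c(Cl)cn2)C1` at 2.2. Compound 3 `CC(=O)N[C@@H]1CCC[C@H](C(=O)Nc2cc(-c3cnn4c3OCCC4)c(Cl)cn2)C1` differs from compound 2 by this change on an aromatic carbon: a group of 9 heavy atoms (6 carbon, 2 nitrogen, 1 oxygen; one five-membered aromatic ring with 2 hetero atoms, one six-membered non-aromatic ring with 2 hetero atoms) in place of a group of 10 heavy atoms (8 carbon, 2 nitrogen; one five-membered aromatic ring with 2 hetero atoms, one seven-membered non-aromatic ring with 1 hetero atom), on an aromatic carbon. For the measured compounds named here, the one measured step that bears on it, a number 1.40 log units higher from compound 1 to compound 2 (beyond the scatter), is large and also exchanges the group on that aromatic carbon. The new group retains the five-membered aromatic ring, but its second ring differs, so a moderate fall beyond the scatter is expected, estimated as a number 0.90 log units lower from compound 2 to compound 3 (beyond the scatter). For compound 3 the expected value is 2.7, with an estimated range of 2.3 to 3.1.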

Compound 3, distribution coefficient: 2.6
Compound 3: the middle estimate sits 0.10 log units above what was measured; low and high end bracket the measured number.
By their numbers in this assay, from the lowest: compound 1; then compound 3; then compound 2.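

In this assay, the value at this aromatic carbon proves to depend on the second ring and not only on the retained five-membered aromatic ring, with a number 1.00 log units lower from compound 2 to compound 3 (beyond the scatter) for the six-membered ring with 2 hetero atoms in place of the seven-membered one. That group still keeps the number up relative to the group with no second ring, with a number 0.40 log units higher from compound 1 to compound 3 (beyond the scatter) on the same carbon. Nothing available here accounts for either step.

The step from the seven-membered ring changes ring size and brings in oxygen together, and the compounds shown do not tell these two apart. Going by these compounds, how a six-membered second ring of carbon alone, or a second ring carrying an amine, would read remains open.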